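Cytotoxicity in the series: compound 4 expected

This account rests on a few compounds, and the source may have more. Where it says the series, first, only, none or still open, it means among the compounds named here.

Measured compounds:
- Compound 1 `CCOC(=O)c1cnc(N2CCN(Cc3ccc(C(F)(F)F)cc3)CC2)nc1Oc1c(C)cc(-c2ccc(C#N)cc2)cc1C`. In an ADME assay on MT4 cells (Homo sapiens) for cytotoxicity, read by MTT assay, with a stated time of 4 days (on this read-out lower numbers stand for higher toxicity in this test and higher numbers for lower toxicity in this test), compound 1 gives > 125000 nM, which is a limit of the assay and not a number.
- Compound 2 `CCOC(=O)c1cnc(N2CCN(Cc3cccc(C(F)(F)F)c3)CC2)nc1Oc1c(C)cc(-c2ccc(C#N)cc2)cc1C`. In this assay compound 2 gives > 125000 nM, again a limit.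
- Compound 3 `CCOC(=O)c1cnc(N2CCN(Cc3ccc(Br)cc3)CC2)nc1Oc1c(C)cc(-c2ccc(C#N)cc2)cc1C`. In this assay compound 3 gives > 125000 nM, again a limit.

Compound 2 therefore stands at a limit only, and the two other values shown are limits as well, all three sitting at the limit of > 125000 nM in this assay, at which 3 of the 3 values shown sit. The steps among the measured compounds cannot be read: a step that the two limits leave unreadable from compound 1 to compound 2, a step that the two limits leave unreadable from compound 1 to compound 3 and a step that the two limits leave unreadable from compound 2 to compound 3. Among the compounds with values here, no step of measurable size exists in this set.

Compound 4 `CCOC(=O)c1cnc(N2CCN(Cc3cc(C)cc(C)c3)CC2)nc1Oc1c(C)cc(-c2ccc(C#N)cc2)cc1C` is not yet measured. It differs from compound 2 as follows: 3,5-dimethylphenyl in place of 3-(trifluoromethyl)phenyl on a saturated chain carbon bound to an amine nitrogen in a ring. The bearing steps are the three unreadable ones above, which give no size in either direction. Since every measured compound sits at the same limit, the expectation for compound 4 is that it behaves the same way, most likely returning a limit rather than a number in this assay.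

Compound 4 is estimated at 125000 nM in this assay, with a range from 60000 nM to 250000 nM. The expected step is a number no higher from compound 2 to compound 4 (the limit leaves the size open), no change beyond the scatter.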

Compound 4, half-maximal cytotoxic concentration: > 125000 nM
Compound 4: no number, only a limit; the forecaster's own chance of this, stated with the estimate: 85%; the middle value sits exactly at the limit.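

No new step can be read: the steps linking compound 4 with compound 1, compound 2 and compound 3 all join one limit to another, and the shared position is this: the limit of > 125000 nM in this assay, at which 4 of the 4 values shown sit.

The compounds shown leave open at what concentration any of them turns cytotoxic in this assay, and whether changing the benzyl group alters that concentration.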